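The compounds below may be only part of what the source reports. "The series", "measured", "known", "first", "only" and "open" are said of these compounds alone.

The measured compounds:
Compound 1, `Cc1nc(C#Cc2cncc(Br)c2)cs1`, gives 60 nM in a functional assay on CHO cells for agonist activity at metabotropic glutamate receptor 5 (Homo sapiens), read by inositol phosphate accumulation; a lower number here means a stronger inhibitor, a higher number a weaker inhibitor.
Compound 2, `Cc1nc(C#Cc2ccsc2)cs1`, gives 337 nM.
Compound 3, `Cc1nc(C#Cc2cccc(C(N)=O)c2)cs1`, gives 1000 nM.

Compound 1 has the lowest number of the three, and both gaps to it lie beyond the scatter: compound 2 stands nearest, compound 3 furthest. Compound 4, `Cc1nc(C#Cc2cncc(-c3ccc(F)cc3)c2)cs1`, is not yet measured. It differs from compound 1 in one place: 4-fluorophenyl in place of bromo on an aromatic carbon. Within the data shown here, no pair of measured compounds shows a change of this kind, so its effect cannot be read from them. The expected step of a 1.5-fold lower number from compound 1 to compound 4 (0.18 log units; within the scatter) is modest, leaning toward a lower number, and may well fall within the scatter. On that basis compound 4 is expected to give about 40 nM in this assay, with a range from 8 nM to 200 nM.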

Compound 4, half-maximal inhibitory concentration: 162 nM
The estimate for compound 4 lay 4.1-fold (0.61 log units) below the measured number, within the range that was stated.
By their numbers in this assay, from the lowest: compound 1; then compound 4; then compound 2; then compound 3.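

Putting 4-fluorophenyl in place of bromo on this carbon gives a 2.7-fold higher number from compound 1 to compound 4 (0.43 log units; beyond the scatter) in this assay. The position therefore accepts a whole extra aromatic ring, with 7 heavy atoms entering where 1 leaves, at a modest cost in inhibition. Nothing available explains why the number rises.

Whether the fluorine contributes to this result remains open, since a plain phenyl is absent from the compounds shown. It is also unknown how an amine or a methoxy group at this position would compare with bromo.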